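This account rests on a few compounds, and the source may have more. Where it says the series, first, only, none or still open, it means among the compounds named here.

Compound 1 `Cc1oc(-c2c(Br)cccc2Br)nc1CN1CCC(C(=O)NCCCN2C[C@H](C)C[C@H](C)C2)CC1` was examined in a physicochemical assay for permeability, using PAMPA; a higher number here means that the compound crosses the layer faster, a lower number that the compound crosses the layer more slowly. Compound 1 returns only a limit there, < 1 10^-6 cm/s, the point marked by the limit of < 1 10^-6 cm/s in this assay, at which 1 of the 3 values shown sits. Compound 2 `Cc1ccccc1-c1nc(CN2CCC(C(=O)NCCN3C[C@H](C)C[C@H](C)C3)CC2)c(C)o1` gives 712 10^-6 cm/s in this assay. Compound 3 `Cc1ccccc1-c1nc(CN2CCC(C(=O)N3CCN(C4CCN(C)CC4)CC3)CC2)c(C)o1` also sits at a limit in this assay, < 3.2 10^-6 cm/s, the point marked by the limit of < 3.2 10^-6 cm/s in this assay, at which 1 of the 3 values shown sits. Compound 4 `Cc1ccc(-c2nc(CN3CCC(C(=O)NCCCN4C[C@H](C)C[C@H](C)C4)CC3)c(C)o2)c(C)c1` has not yet been measured; it differs from compound 1 by 2,4-dimethylphenyl in place of 2,6-dibromophenyl on an aromatic carbon. Within the data shown here, no pair of measured compounds shares exactly this change, so the size of the step is open. The expected step of an at least 300-fold higher number from compound 1 to compound 4 (2.47 log units; beyond the scatter) is a large rise, well beyond the usual scatter. That expectation rests on compound 2, which gives 712 10^-6 cm/s. In this assay compound 4 is estimated at 300 10^-6 cm/s, with a range from 50 10^-6 cm/s to 900 10^-6 cm/s.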

Compound 4, apparent permeability: 353 10^-6 cm/s
For compound 4 the middle estimate is 1.2-fold (0.07 log units) below the measured one; low and high end bracket the measured number.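

In this assay, among these compounds, the 2,4-dimethylphenyl in place of 2,6-dibromophenyl on this aromatic carbon gives an at least 350-fold higher number from compound 1 to compound 4 (2.54 log units; beyond the scatter), the first step that can be read at this position, with the rest of the structure unchanged. The value of compound 1 is a limit, not a number: the limit of < 1 10^-6 cm/s in this assay, at which 1 of the 4 values shown sits. The aryl group at this position can therefore separate the two compounds by far more than the usual scatter. Since the bromine atoms and the substitution pattern change together, the compounds shown cannot tell these two differences apart. On these data alone, how a plain phenyl or a pyridine ring at this carbon would read remains open.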